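Cytotoxicity of nucleoside analogues with a varied side chain

The source may report more compounds than this note shows. Statements on the series, on what has been measured and on what is new or still open speak of the compounds shown alone.

Measured compounds in a functional assay on Huh-7 cells (Homo sapiens) for cytotoxicity, read by MTT assay, with a stated time of 3 days; a lower number here means that less compound is tolerated, a higher number that more compound is tolerated:
compound 1 `OC[C@H]1O[C@@H](n2cnc3c(COc4ccccn4)ncnc32)[C@H](O)[C@@H]1O` gives > 250000 nM, which is a limit of the assay and not a number.
compound 2 `CN(Cc1ccccc1)Cc1ncnc2c1ncn2[C@@H]1O[C@H](CO)[C@@H](O)[C@H]1O` gives 9000 nM.
compound 3 `OC[C@H]1O[C@@H](n2cnc3c(CSc4ccccc4)ncnc32)[C@H](O)[C@@H]1O` gives > 100000 nM, again a limit rather than a number.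

Compound 1 thus stands only as a limit, the higher of the two limits reached here. Compound 4 `O=C(O)CNCc1ncnc2c1ncn2[C@@H]1O[C@H](CO)[C@@H](O)[C@H]1O` differs from it by (carboxymethyl)amino in place of (pyridin-2-yl)oxy on a saturated chain carbon bound to an aromatic carbon. The step that bears on this is an at least 27-fold lower number from compound 1 to compound 2 (1.44 log units; beyond the scatter), where an amine entered at the same carbon; an at least 11-fold higher number from compound 2 to compound 3 (1.04 log units; beyond the scatter) and a step that the two limits leave unreadable from compound 1 to compound 3 show how unreadable the limits leave the rest. Compound 4 carries an amine like compound 2 but with an acid, so its expected value in this assay is 150000 nM, within 30000 nM to 400000 nM. That estimate means an at least 1.6-fold lower number from compound 1 to compound 4 (0.22 log units; that floor lies within the scatter).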

Compound 4, half-maximal cytotoxic concentration: > 100000 nM
Compound 4 was reported as a limit (the forecaster's own chance of this, stated with the estimate: 60%); the middle value does not contradict the limit.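

An amine at this saturated chain carbon bound to an aromatic carbon does not by itself go with the lower number: in this assay, (carboxymethyl)amino in place of benzyl(methyl)amino gives an at least 11-fold higher number from compound 2 to compound 4 (1.04 log units; beyond the scatter). Compound 4 stands only as a limit, and the steps to it from compound 1 and compound 3 cannot be read. Compound 2 remains the only compound of the four with a number rather than a limit: the limit of > 100000 nM in this assay, at which 2 of the 4 values shown sit.

Open, as far as these compounds go, is whether the carboxylic acid or the missing benzyl group carries this step. Also open, from the compounds shown here alone, is where a plain dimethylamino group, or a longer chain ending in a carboxylic acid, would stand at this carbon.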